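Lengthening the Pyrrolidine Chain of Compound 3

The source may hold more compounds than are shown below. What is called first, only, known or untested is meant among the compounds shown, and "the series" means these compounds.

Measured in a functional assay on HepG2 cells (Homo sapiens) for antiproliferative activity, read by MTT assay, with a stated time of 48 h (a lower number here means a stronger inhibitor, a higher number a weaker inhibitor), so far:
Compound 1 `COc1cc2oc(-c3ccccc3)cc(=O)c2c(O)c1OCCCN1CCCCC1` at 22300 nM
Compound 2 `O=c1cc(-c2ccccc2)oc2cc(O)c(OCCCCN3CCCC3)c(O)c12` at > 100000 nM as a limit of the assay
Compound 3 `COc1cc2oc(-c3ccccc3)cc(=O)c2c(O)c1OCCCN1CCCC1` at 4300 nM

Compound 3 at 4300 nM holds the lower of the two actual numbers, and compound 1 stands higher at 22300 nM. The remaining reading, compound 2 at > 100000 nM, is only a limit of the assay. Compound 4 `COc1cc2oc(-c3ccccc3)cc(=O)c2c(O)c1OCCCCN1CCCC1` has not yet been measured and differs from compound 3 by (pyrrolidin-1-yl)methyl in place of pyrrolidin-1-yl on a saturated chain carbon, three bonds along the chain from an oxygen on an aromatic ring on the chain, so that 3-(pyrrolidin-1-yl)propyl becomes 4-(pyrrolidin-1-yl)butyl.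

Within the data shown here, one measured step touches this chain end, namely a 5.2-fold lower number from compound 1 to compound 3 (0.71 log units; beyond the scatter) with pyrrolidin-1-yl in place of piperidin-1-yl. That step changes the ring and not the chain, so it gauges only how far a small change here can move the number. The lean toward a higher number rests solely on compound 2, which carries the same 4-(pyrrolidin-1-yl)butyl group and sits at > 100000 nM as a limit of the assay, though its core differs. A modest move is therefore expected, estimated as a 2.1-fold higher number from compound 3 to compound 4 (0.32 log units; beyond the scatter) in this assay for this chain extension. For compound 4 the estimated value is 9000 nM with an expected range of 2500 nM to 32000 nM around it.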

Compound 4, half-maximal inhibitory concentration: 4900 nM
For compound 4 the middle estimate is 1.8-fold (0.26 log units) above the measured one, within the range that was stated.
By their numbers in this assay, from the lowest: compounds 3 and 4 (each within the scatter of the next); then compound 1. At a limit, above all of these: compound 2.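

In this assay the extension from 3-(pyrrolidin-1-yl)propyl to 4-(pyrrolidin-1-yl)butyl, three bonds along the chain from an oxygen on an aromatic ring, gives a 1.1-fold higher number from compound 3 to compound 4 (0.06 log units; within the scatter), so the two compounds cannot be told apart, while the longer chain still shows a 4.6-fold lower number from compound 1 to compound 4 (0.66 log units; beyond the scatter). The weak reading of compound 2 therefore does not carry over to the 4-(pyrrolidin-1-yl)butyl group on the core of compound 4: with methyl in place of hydrogen on an oxygen on an aromatic ring as the one difference, this assay gives an at least 20-fold lower number from compound 2 to compound 4 (1.30 log units; beyond the scatter). The reading of compound 2 is only a limit of the assay, so this step has a floor and no exact size: the limit of > 100000 nM in this assay, at which 1 of the 4 values shown sits.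

The compounds shown leave open whether the number would hold with a shorter 2-(pyrrolidin-1-yl)ethyl chain or a longer pentyl chain carrying the same pyrrolidine. They also leave open whether a piperidine on the butyl chain, or another amine such as morpholine or dimethylamine at this chain end, would stay in the range of compound 3 and compound 4.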